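Moving One Fluorine on the Difluorophenyl Group

This account rests on a few compounds, and the source may have more. Where it says the series, first, only, none or still open, it means among the compounds named here.

Measured compounds:
compound 1 `CC(C)N1CCN(Cc2csc(N)c2C(=O)c2ccc(Cl)cc2)CC1`, 3.6%
compound 2 `Nc1scc(CN2CCN(c3ccccc3F)CC2)c1C(=O)c1ccc(Cl)cc1`, -1%
compound 3 `Nc1scc(CN2CCN(c3ccc(F)cc3F)CC2)c1C(=O)c1ccc(Cl)cc1`, -17%

In a functional assay on CHO cells with adenosine receptor A1 (Homo sapiens) as the target, read by cAMP accumulation and immunoassay, with a stated time of 6 min, tested at 0.1 uM (a higher number here means a weaker effect of the compound at the concentration tested, a lower number a stronger effect), compound 3 holds the lowest of the three numbers. Its nearest neighbour is compound 2, and the step of a number 16 percentage points lower from compound 2 to compound 3 (beyond the scatter) lies beyond the scatter; the wider step a number 20.6 percentage points lower from compound 1 to compound 3 (beyond the scatter) also lies beyond it, while a number 4.6 percentage points lower from compound 1 to compound 2 (within the scatter) is within the scatter. Compound 4 `Nc1scc(CN2CCN(c3cc(F)ccc3F)CC2)c1C(=O)c1ccc(Cl)cc1` is not yet measured. It differs from compound 3 only in 2,5-difluorophenyl in place of 2,4-difluorophenyl on an amine nitrogen in a ring. Both steps that bear on this change are modest, and the new compound keeps the same atoms. Compound 4 is therefore expected to give about -10% in this assay, with a range from -30% to 10%. The expected step of a number 7 percentage points higher from compound 3 to compound 4 (within the scatter) stays within the scatter.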

Compound 4, a percentage reported as activity, at one concentration (the size of the read-out at that concentration, not a potency): -13%
For compound 4 the middle estimate is 3 percentage points above the measured one, within the range that was stated.
By their numbers in this assay, from the lowest: compounds 3 and 4 (each within the scatter of the next); then compounds 2 and 1 (each within the scatter of the next).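

In this assay, shifting one fluorine, with 2,5-difluorophenyl in place of 2,4-difluorophenyl, gives no change beyond the scatter (a number 4 percentage points higher from compound 3 to compound 4 (within the scatter)). The second fluorine also separates the new compound from the monofluorinated one (a number 12 percentage points lower from compound 2 to compound 4 (beyond the scatter)), so that separation is not confined to the 2,4-difluorophenyl arrangement. The 2,5-difluorophenyl group likewise stands apart from isopropyl (a number 16.6 percentage points lower from compound 1 to compound 4 (beyond the scatter)). No available evidence accounts for these steps. Going by these compounds, what a nitrile or a methoxy group would give on this aromatic ring in place of either fluorine stays open.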